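Trifluoromethyl for fluoro: working notes on compound 4

The source may report more compounds than this note shows. Statements on the series, on what has been measured and on what is new or still open speak of the compounds shown alone.

Measured in a functional assay on QGY-7703 cells (Homo sapiens) for cytotoxicity, read by MTT assay, with a stated time of 24 h; a higher number here means a weaker inhibitor, a lower number a stronger inhibitor:
- Compound 1 `CN1C/C(=C\c2cccnc2)C(=O)/C(=C/c2ccccc2C(F)(F)F)C1` gives 2910 nM
- Compound 2 `CN1C/C(=C\c2ccncc2)C(=O)/C(=C/c2ccccc2F)C1` gives 4900 nM
- Compound 3 `CN1C/C(=C\c2ccncc2)C(=O)/C(=C/c2ccc(F)cc2Br)C1` gives 6900 nM

In this assay compound 2 at 4900 nM lies within the scatter of both compound 1 and compound 3, so it holds no clearly separate place among the three.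

The open question is compound 4 `CN1C/C(=C\c2ccncc2)C(=O)/C(=C/c2ccccc2C(F)(F)F)C1` and its relation to compound 2. The change is trifluoromethyl in place of fluoro on an aromatic carbon and amounts to trifluoromethyl in place of fluoro on an aromatic carbon, ortho to a large group.

One measured step falls on the same aromatic ring. Exchanging 2-fluorophenyl for 2-bromo-4-fluorophenyl gives a 1.4-fold higher number from compound 2 to compound 3 (0.15 log units; within the scatter) and so moves nothing beyond the scatter. For the measured compounds named here, compound 1 also carries trifluoromethyl and gives 2910 nM yet no measured step isolates that group. The evidence is thin, and neither observation points to a large effect.

The expected shift is a 1.3-fold lower number from compound 2 to compound 4 (0.11 log units; within the scatter) in this assay and so nothing beyond the scatter. For compound 4 the estimated value is 3800 nM with an expected range (1900 nM to 7500 nM).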

Compound 4, half-maximal inhibitory concentration: 4500 nM
Beside the measured number, compound 4's estimate is 1.2-fold (0.07 log units) below it; low and high end bracket the measured number.
By their numbers in this assay, from the lowest: compounds 1, 4, 2 and 3 (each within the scatter of the next, the first and the last beyond it).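

In this assay, for the compounds shown here, trifluoromethyl in place of fluoro on an aromatic carbon, ortho to a large group, gives a 1.1-fold lower number from compound 2 to compound 4 (0.04 log units; within the scatter) and thereby isolates this group for the first time: at this position the exchange of fluoro for the larger trifluoromethyl leaves the reading within the scatter. Going by these compounds alone, with trifluoromethyl held constant, pyridin-4-yl in place of pyridin-3-yl gives a 1.5-fold higher number from compound 1 to compound 4 (0.19 log units; within the scatter) and so provides the first single-place reading of the pyridine pair, which also stays within the scatter, so neither exchange separates its two compounds in this cytotoxicity read-out. No accompanying measurement offers an explanation for either reading.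

All the groups shown on this aromatic ring contain halogen, so it remains open whether an amine or a carboxylic acid at the same aromatic carbon would shift the number beyond the scatter. Also open, on these data alone, is whether a longer chain in place of the methyl group on the shared core, or a plain phenyl in place of the pyridine, would separate from compound 4 in this assay.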